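An Aryl Exchange on the Shared Core

The source may report more compounds than this note shows. Statements on the series, on what has been measured and on what is new or still open speak of the compounds shown alone.

In a functional assay on U-87MG ATCC cells for antiproliferative activity against U-87 MG (Homo sapiens), read by MTT assay, with a stated time of 48 h (a higher number here means a weaker inhibitor, a lower number a stronger inhibitor), compound 1 (`COc1ccc(-c2nc(SCC(=O)c3sc(-c4ccc(Cl)cc4)nc3C)[nH]c(=O)c2C#N)cc1`) gives 35500 nM and compound 2 (`COc1ccc(-c2nc(SCC(=O)c3sc(-c4ccc(Cl)cc4)nc3C)[nH]c(=O)c2C#N)cc1OC`) gives 38600 nM, which places them within the scatter of each other. Among the measured compounds shown here, the only measured step, a 1.1-fold higher number from compound 1 to compound 2 (0.04 log units; within the scatter), is methoxy in place of hydrogen on an aromatic carbon. Compound 3 (`Cc1nc(-c2ccc(Cl)cc2)sc1C(=O)CSc1nc(-c2ccc(Cl)cc2)c(C#N)c(=O)[nH]1`) has 4-chlorophenyl in place of 3,4-dimethoxyphenyl on an aromatic carbon. For the measured compounds named here, no measured step makes this exchange. With compound 2 at 38600 nM as the anchor, no change beyond the scatter is expected in this assay. The estimated step is a 1.4-fold lower number from compound 2 to compound 3 (0.14 log units; within the scatter). Compound 3 is expected at 28000 nM, within 11000 nM to 65000 nM.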

Compound 3, half-maximal inhibitory concentration: 53000 nM
Beside the measured number, compound 3's estimate is 1.9-fold (0.28 log units) below it; the measured number falls inside the stated range.
By their numbers in this assay, from the lowest: compounds 1, 2 and 3 (each within the scatter of the next).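

Exchanging 3,4-dimethoxyphenyl for 4-chlorophenyl on this aromatic carbon, next to the ring nitrogen, gives a 1.4-fold higher number from compound 2 to compound 3 (0.14 log units; within the scatter) in this assay, and chloro in place of methoxy gives a 1.5-fold higher number from compound 1 to compound 3 (0.17 log units; within the scatter). Both steps lie within the scatter, so the aryl group here can carry either chloro or methoxy, with two hydrogen-bond acceptors or none, without a step beyond the scatter. No evidence bears on this result.

From the compounds shown here alone, what an amine or a carboxylic acid on this aryl ring would give remains open. So does the effect of changing the aryl group to a saturated ring.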